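The source may hold more compounds than are shown below. What is called first, only, known or untested is meant among the compounds shown, and "the series" means these compounds.

Working notes on the series. Compound 1 `COC(=O)[C@@]1(C)CCC=C2[C@@H]1CC[C@@H](C)[C@]2(C)Cc1c[nH]c2ccc(Br)cc12` is the weakest of the three measured compounds in a functional assay on HeLa cells (Homo sapiens) for inhibition, read by sulforhodamine B assay, with a stated time of 48 h; a higher number here means a weaker inhibitor of growth, a lower number a stronger inhibitor of growth: compound 1 gives 10000 nM. Compound 2 `COC(=O)[C@@]1(C)CCC=C2[C@@H]1CC[C@@H](C)[C@]2(C)Cc1c[nH]c2ccc(F)cc12` gives 3700 nM in this assay, and compound 3 `COC(=O)[C@@]1(C)CCC=C2[C@@H]1CC[C@@H](C)[C@]2(C)Cc1c[nH]c2ccc(OC)cc12` gives 1200 nM. Compound 1 thus stands highest, with compound 2 nearest and compound 3 furthest away. All three measured steps change the substituent on the same aromatic carbon and are of modest size: a 2.7-fold lower number from compound 1 to compound 2 (0.43 log units; beyond the scatter), an 8.3-fold lower number from compound 1 to compound 3 (0.92 log units; beyond the scatter) and a 3.1-fold lower number from compound 2 to compound 3 (0.49 log units; beyond the scatter).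

Compound 4 `COC(=O)[C@@]1(C)CCC=C2[C@@H]1CC[C@@H](C)[C@]2(C)Cc1c(C)[nH]c2ccc(Br)cc12` keeps the bromo of compound 1 and differs from compound 1 in one place: methyl in place of hydrogen on an aromatic carbon. Going by the values given here, none of the measured steps touches this carbon, so no step among them bears directly on the change; the measured steps only show the size of effect this series has produced so far from single substitutions on an aromatic carbon. Among the compounds with values here, with no guiding step, the expected outcome in this assay for the move from compound 1 to compound 4 is no step beyond the scatter, and the step expected is no change at the digits printed from compound 1 to compound 4 (within the scatter). Compound 4 is therefore estimated at 10000 nM in this assay. The expected range for compound 4 runs from 3000 nM to 30000 nM.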

Compound 4, concentration for 50% growth inhibition: 11000 nM
Beside the measured number, compound 4's estimate is 1.1-fold (0.04 log units) below it; measured number inside the range.
By their numbers in this assay, from the lowest: compound 3; then compound 2; then compounds 1 and 4 (each within the scatter of the next).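

In this assay, methyl in place of hydrogen on the aromatic carbon next to the ring nitrogen gives a 1.1-fold higher number from compound 1 to compound 4 (0.04 log units; within the scatter) and so leaves compounds 1 and 4 within the scatter of each other. Going by these compounds alone, this is the first view of a second place on the five-membered aromatic ring, and unlike the steps among compounds 1, 2 and 3, all beyond the scatter and all on the carbon bearing bromo in compound 1, this single substitution does not separate the two compounds, even on a carbon next to the ring atom that bears a large group. No measurement shown here gives any explanation of this result.

The compounds shown leave open whether another group on this carbon, such as an ethyl group, a longer chain, an amine or a carboxylic acid, would also stay within the scatter of compound 1. They also leave open whether methyl on this carbon gives the same outcome with the fluoro of compound 2 or the methoxy of compound 3 in place of bromo, since only the bromo pair is shown.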